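From 4-chloropiperidin-1-yl to dipentylamino

This account rests on a few compounds, and the source may have more. Where it says the series, first, only, none or still open, it means among the compounds named here.

Compound 1 `COc1ccc(/C=C/c2cc(OC)cc(OC)c2/C=C/C(=O)N2CCCCC2C)cc1`: 4350 nM
Compound 2 `COc1ccc(/C=C/c2cc(OC)cc(OC)c2/C=C/C(=O)N2CCC(Cl)CC2)cc1`: 4950 nM
Compound 3 `COc1ccc(/C=C/c2cc(OC)cc(OC)c2/C=C/C(=O)Nc2cc(OC)c(OC)c(OC)c2)cc1`: 7010 nM

These three compounds were tested in a functional assay on MCF7 cells (Homo sapiens) for inhibition, read by MTT assay, with a stated time of 48 h; on this read-out higher numbers stand for weaker inhibition and lower numbers for stronger inhibition. Compound 2, at 4950 nM, lies within the scatter of both compound 1 and compound 3. Compound 4 `CCCCCN(CCCCC)C(=O)/C=C/c1c(/C=C/c2ccc(OC)cc2)cc(OC)cc1OC` carries dipentylamino in place of 4-chloropiperidin-1-yl on a carbonyl carbon. Within the data shown here, only one measured step bears on this change: a 1.1-fold higher number from compound 1 to compound 2 (0.06 log units; within the scatter). Among the measured compounds shown here, that step swaps one ring group for another, and no measured compound has a group without a ring at this place, so the data leave the new group untested. On that limited evidence, no step beyond the scatter is expected in this assay. The expected step is a 1.0-fold higher number from compound 2 to compound 4 (0.00 log units; within the scatter). For compound 4 the estimated value is 5000 nM, with an expected range of 2000 nM to 12500 nM.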

Compound 4, half-maximal inhibitory concentration: 6130 nM
The estimate for compound 4 lay 1.2-fold (0.09 log units) below the measured number; measured number inside the range.
By their numbers in this assay, from the lowest: compounds 1, 2, 4 and 3 (each within the scatter of the next).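

In this assay, among these compounds, dipentylamino is the first group without a ring on this carbonyl carbon, and the change stays within the scatter, with a 1.2-fold higher number from compound 2 to compound 4 (0.09 log units; within the scatter) and a 1.4-fold higher number from compound 1 to compound 4 (0.15 log units; within the scatter) as the two steps. Among these compounds, then, replacing either piperidine-based group with this open chain does not move the number beyond the scatter. Nothing given here offers an explanation for this result.

Going by these compounds, whether a shorter chain such as diethylamino would also stay within the scatter remains open. The same holds for a chain ending in an amine or a carboxylic acid.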